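The source may hold more compounds than are shown below. What is called first, only, known or untested is meant among the compounds shown, and "the series" means these compounds.

Measured in a functional assay on A549 cells (Homo sapiens) for inhibition, read by sulforhodamine B assay, with a stated time of 72 h (on this read-out higher numbers stand for weaker inhibition and lower numbers for stronger inhibition), so far:
- compound 1 `COc1cc2c(Nc3ccc(F)c(Cl)c3)ncnc2cc1OCCCn1ccnc1[N+](=O)[O-]` gives 4310 nM
- compound 2 `C#Cc1cccc(Nc2ncnc3cc(OCCCCn4ccnc4[N+](=O)[O-])c(OC)cc23)c1` gives 1080 nM
- compound 3 `COc1cc2c(Nc3cccc(Br)c3)ncnc2cc1OCCCn1ccnc1[N+](=O)[O-]` gives 7830 nM

Compound 3 stands level with compound 1 and well above compound 2 in number. Compound 4 `COc1cc2c(Nc3cccc(Br)c3)ncnc2cc1OCCCCn1ccnc1[N+](=O)[O-]` differs from compound 3 in one place: (2-nitro-1H-imidazol-1-yl)methyl in place of 2-nitro-1H-imidazol-1-yl on a saturated chain carbon, three bonds along the chain from an oxygen on an aromatic ring and nothing else.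

Among the compounds with values here, no measured single-place step covers this change. Within the data shown here, the only such step, a 1.8-fold higher number from compound 1 to compound 3 (0.26 log units; within the scatter) and so no real separation, concerns the group on the nitrogen and not the chain. Compound 2 alone carries the chain of compound 4, but it differs from compound 3 in two places. Against compound 3 at 7830 nM in this assay compound 2 reads 1080 nM and so sets only a loose guide. A move to a lower number is expected, smaller than that gap. The expected change is a 2.6-fold lower number from compound 3 to compound 4 (0.42 log units; beyond the scatter) and no more than that. Compound 4 is estimated at 3000 nM with an expected range from 1000 nM to 8000 nM on this reasoning.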

Compound 4, half-maximal inhibitory concentration: 1970 nM
Beside the measured number, compound 4's estimate is 1.5-fold (0.18 log units) above it; the measured number falls inside the stated range.
By their numbers in this assay, from the lowest: compounds 2 and 4 (each within the scatter of the next); then compounds 1 and 3 (each within the scatter of the next).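

In this assay, within the data shown here, the step at this saturated chain carbon gives the first single-place reading on the chain (a 4.0-fold lower number from compound 3 to compound 4 (0.60 log units; beyond the scatter)): with the 3-bromophenyl group held constant, the (2-nitro-1H-imidazol-1-yl)methyl change moves the number by more than the scatter. On this same chain, bromo in place of ethynyl on an aromatic carbon does not separate the two compounds (a 1.8-fold higher number from compound 2 to compound 4 (0.26 log units; within the scatter)), so the aromatic substituent shows no measurable effect here, as the 3-bromophenyl and 3-chloro-4-fluorophenyl groups showed none on the shorter chain. No measured information at hand accounts for the chain step.

Going by these compounds, whether the trend continues with a still longer chain remains open, as does whether it holds with the 3-chloro-4-fluorophenyl group. Also open, on these data alone, is whether the chain step depends on the 2-nitro-1H-imidazol-1-yl group or would persist with an amine in its place.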